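Bromo for chloro on the weakly active series

The source may report more compounds than this note shows. Statements on the series, on what has been measured and on what is new or still open speak of the compounds shown alone.

Measured so far in a functional assay on thoracic aorta (Rattus norvegicus, strain Wistar), with a stated time of 15 min; on this read-out higher numbers stand for an effect only at larger amounts of compound and lower numbers for an effect already at smaller amounts:
- compound 1 `CCOc1ccc(Cl)cc1C(C)NC(=O)NS(=O)(=O)c1ccc(C)cc1` gives > 300000 nM (a limit)
- compound 2 `COc1ccc(Cl)cc1C(C)NC(=O)NS(=O)(=O)c1ccc(C)cc1` gives > 300000 nM (a limit)
- compound 3 `CCOc1ccc(Cl)cc1C(C)NC(=O)NS(=O)(=O)c1ccc(Cl)cc1` gives 281000 nM (a number)

Compound 1 has no number, only a limit, > 300000 nM, in this assay as its entry. Among the compounds with values here, the series so far is summed up by the limit of > 300000 nM in this assay, at which 2 of the 3 values shown sit, and compound 3 alone has a number.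

Compound 4 `CCOc1ccc(Br)cc1C(C)NC(=O)NS(=O)(=O)c1ccc(C)cc1` keeps the core of compound 1 and carries bromo in place of chloro on an aromatic carbon, para to an ethoxy group (bromo in place of chloro on an aromatic carbon). Within the data shown here, no measured step touches this position, so the evidence is indirect. The ethoxy-to-methoxy change is a step that the two limits leave unreadable from compound 1 to compound 2, which gives no size. Among the measured compounds shown here, the exchange of chloro for methyl on an aromatic carbon is an at least 1.0-fold lower number from compound 1 to compound 3 (0.02 log units; that floor lies within the scatter), the only step with a readable size, and it stays within the scatter. On that basis, no step beyond the scatter is expected in this assay, and a further limit is more likely than a number. The estimated step is a number no higher from compound 1 to compound 4 (the limit leaves the size open), with no direction expected beyond the scatter. For compound 4 the estimated value is 300000 nM, with an expected range from 120000 nM to 600000 nM in this read-out.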

Compound 4, half-maximal effective concentration: > 300000 nM
Compound 4 ended at the assay's limit; the forecaster's own chance of this, stated with the estimate: 60%; the middle value lies on the limit itself.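

In this assay compound 4 gives > 300000 nM, a limit and not a number. Within the data shown here, compound 1 also stands at a limit, so no step between compound 1 and compound 4 can be read. The compounds shown leave open what bromo in place of chloro on an aromatic carbon does to the read-out, and the series remains summed up by one entry: the limit of > 300000 nM in this assay, at which 3 of the 4 values shown sit.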